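Replacing the acyl group of compound 2 with pyridin-3-yl

The compounds below may be only part of what the source reports. "The series", "measured", "known", "first", "only" and "open" are said of these compounds alone.

Compound 1 (`CN(C)c1ccc(C(=O)N(CC(=O)NCc2ccccc2)Cc2ccc(C(=O)Nc3cc(-c4ccccc4)ccc3N)cc2)cc1`) gives 11100 nM in a functional assay on CAL-27 cells (Homo sapiens) for cytotoxicity, read by MTT assay, with a stated time of 72 h; on this read-out higher numbers stand for weaker inhibition and lower numbers for stronger inhibition
Compound 2 (`CN(C)c1ccc(C(=O)N(CC(=O)NCc2ccccc2)Cc2ccc(C(=O)Nc3ccccc3N)cc2)cc1`) gives 1600 nM in this assay

Within the data shown here, compound 2 stands at 1600 nM in this assay and this is the lower of the two numbers so far. Among the measured compounds shown here, the only measured step is a 6.9-fold lower number from compound 1 to compound 2 (0.84 log units; beyond the scatter) and it lies beyond the scatter. That step is hydrogen in place of phenyl on an aromatic carbon, so it sits elsewhere in the molecule.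

Compound 3 (`Nc1ccccc1NC(=O)c1ccc(CN(CC(=O)NCc2ccccc2)C(=O)c2cccnc2)cc1`) is still unmeasured. Its difference from compound 2 is pyridin-3-yl in place of 4-(dimethylamino)phenyl on a carbonyl carbon and in words it is pyridin-3-yl in place of 4-(dimethylamino)phenyl on a carbonyl carbon. For the measured compounds named here, no measured step touches this carbonyl, so the data give no direct size for the change. Going by the values given here, the step of a 6.9-fold lower number from compound 1 to compound 2 (0.84 log units; beyond the scatter) shows only that a single change can move this series modestly. With nothing pointing either way, no shift beyond the scatter is expected. The expected step is a 1.4-fold higher number from compound 2 to compound 3 (0.14 log units; within the scatter) in this assay and the direction is only a weak guess. Compound 3 is estimated at 2200 nM with 700 nM as the expected lower end and 7000 nM as the expected upper end of the range.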

Compound 3, half-maximal inhibitory concentration: 11200 nM
Compound 3: middle estimate off by 5.1-fold (0.71 log units), on the low side, and the stated range ends below it.
By their numbers in this assay, from the lowest: compound 2; then compounds 1 and 3 (each within the scatter of the next).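

Among these compounds, the carbonyl position, which no earlier step had touched, proves responsive in this assay: pyridin-3-yl in place of 4-(dimethylamino)phenyl gives a 7.0-fold higher number from compound 2 to compound 3 (0.85 log units; beyond the scatter). Among the compounds shown here, this is the first sign that the group on this carbonyl carbon, and not only the phenyl substituent changed elsewhere in the molecule, helps set the number, and the lower number belongs to the compound carrying 4-(dimethylamino)phenyl. The material at hand offers no measurement that would explain this shift.

The exchange replaces a carbon-only ring with a ring holding a hetero atom and removes the dimethylamino group in one move, so compound 2 and compound 3 cannot show which of these changes accounts for the step. As far as these compounds go, a plain phenyl group on the same carbonyl would help separate the two, while it remains open whether a simple aliphatic amine such as piperidine could take the place of the aromatic group and how pyridin-3-yl would behave with the phenyl substituent of compound 1 present.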